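A Chlorine on the Phenyl Arm of Compound 1

A few compounds are considered here, and "the series" means these few. Any claim that something is new, unique, unknown or untested is made for them only; others in the source may bear on it.

Compound 1 `CC1CCN(c2nc(-c3ccccc3)nc3ccccc23)CC1` was tested in a functional assay on the whole organism for inhibition, with Rattus norvegicus as the target, read by paw edema, with stated times of 4 days, 1 h and 2 h, at a dose of 100 mg/kg by the oral route (on this read-out higher numbers stand for more inhibition at the one dose given (going by the name of the read-out) and lower numbers for less inhibition), and gives 69%, the highest of the three numbers measured. Compound 2 `CC1CCN(c2nc(-c3ccccc3)nc3ccc(Br)cc23)CC1` gives 57.8% and compound 3 `CC1CCN(c2nc(-c3ccccc3)nc3ccc(I)cc23)CC1` gives 56.4%. Going by the values given here, the only measured steps are halogens entering the shared core: a number 11.2 percentage points lower from compound 1 to compound 2 (beyond the scatter) and a number 12.6 percentage points lower from compound 1 to compound 3 (beyond the scatter), while a number 1.4 percentage points lower from compound 2 to compound 3 (within the scatter) lies within the scatter. Compound 4 `CC1CCN(c2nc(-c3ccc(Cl)cc3)nc3ccccc23)CC1` differs from compound 1 by chloro in place of hydrogen on an aromatic carbon. Among the compounds with values here, no measured step places a halogen on this ring, so the bromo and iodo steps guide only loosely; a drop in the same direction, somewhat smaller, is expected. Compound 4 is therefore expected to give 60%, within a range of 45% to 73%, which amounts to a number 9 percentage points lower from compound 1 to compound 4 (within the scatter).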

Compound 4, a percentage reported as inhibition, in the whole organism at one dose (the size of the read-out at that dose, not a potency): 55.1%
For compound 4 the middle estimate is 4.9 percentage points above the measured one; low and high end bracket the measured number.
By their numbers in this assay, from the lowest: compounds 4, 3 and 2 (each within the scatter of the next); then compound 1.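

In this assay, phenyl changing to 4-chlorophenyl gives a number 13.9 percentage points lower from compound 1 to compound 4 (beyond the scatter), so a fall beyond the scatter is no longer confined to halogens on the shared core. This ring also responds to a single chlorine, and compound 1, with no halogen at all, stays clearly above each of the three halogen-bearing compounds. Nothing available explains why the number falls at this position. The compounds shown leave open whether a methoxy group or an amine in place of the chlorine would also lower the number, or whether only halogens do so.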